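The source may report more compounds than this note shows. Statements on the series, on what has been measured and on what is new or still open speak of the compounds shown alone.

In a functional assay (trachea) with Cavia porcellus as the target (a lower number here means a stronger inhibitor, a higher number a weaker inhibitor), compound 1 (`Cn1nc(-c2cccnc2)c2ccccc2c1=O`) gives 11500 nM, compound 2 (`CC(C)=CCn1nc(-c2cccnc2)c2ccccc2c1=O`) gives 1380 nM and compound 3 (`O=c1c2ccccc2c(-c2cccnc2)nn1Cc1cccc(Cl)c1`) gives 4170 nM, the middle of the three numbers. Compound 4 (`COCCn1nc(-c2cccnc2)c2ccccc2c1=O`) is not yet measured. Its difference from compound 3 is methoxymethyl in place of 3-chlorophenyl on a saturated chain carbon bound to an aromatic nitrogen. Three modest steps at this place bear on it: a 2.8-fold lower number from compound 1 to compound 3 (0.44 log units; beyond the scatter), an 8.3-fold lower number from compound 1 to compound 2 (0.92 log units; beyond the scatter) and a 3.0-fold higher number from compound 2 to compound 3 (0.48 log units; beyond the scatter). For the measured compounds named here, no measured compound carries methoxymethyl here, so the direction stays open and no step beyond the scatter is expected. The estimated step is a 1.2-fold higher number from compound 3 to compound 4 (0.08 log units; within the scatter). For compound 4 the expected value is 5000 nM, with an estimated range of 1800 nM to 14000 nM.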

Compound 4, half-maximal inhibitory concentration: 9330 nM
The estimate for compound 4 lay 1.9-fold (0.27 log units) below the measured number; low and high end bracket the measured number.
By their numbers in this assay, from the lowest: compound 2; then compound 3; then compounds 4 and 1 (each within the scatter of the next).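

Adding a group on the saturated chain carbon does not by itself lower the number in this assay: methoxymethyl gives a 1.2-fold lower number from compound 1 to compound 4 (0.09 log units; within the scatter), so it goes against the lowering seen with the other two groups. The same place separates the groups, with a 6.8-fold higher number from compound 2 to compound 4 (0.83 log units; beyond the scatter) and a 2.2-fold higher number from compound 3 to compound 4 (0.35 log units; beyond the scatter). No evidence on why methoxymethyl differs from 2-methylprop-1-en-1-yl or 3-chlorophenyl is available. As far as these compounds go, whether a longer ether chain, an amine or a carboxylic acid at this place tracks methoxymethyl or 2-methylprop-1-en-1-yl remains open.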